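Taking the Fluoro Group Off Compound 3

The source may report more compounds than this note shows. Statements on the series, on what has been measured and on what is new or still open speak of the compounds shown alone.

Of the compounds shown here, three sharing one core have been measured in an assay on Sf9 cells for inhibition of protein deacetylase HDAC6 (Homo sapiens), read by fluorescence, with a stated time of 40 min, tested at 100 nM; a lower number here means less inhibition, a higher number more inhibition at the concentration tested (going by the name of the read-out). Compound 1 `COc1ccc(-n2nc(-c3ccccc3)nc2CNc2ccc(C(=O)NO)cc2)cc1` gives 63.4%. Compound 2 `O=C(NO)c1ccc(NCc2nc(-c3cccc(Cl)c3)nn2-c2ccccc2)cc1` gives 61.2%. Compound 3 `O=C(NO)c1ccc(NCc2nc(-c3ccc(F)cc3)nn2-c2ccccc2)cc1` gives 70.9%. Compound 3 has the highest of the three numbers, but both others lie within the scatter of it, compound 1 nearest and compound 2 furthest, so no real ordering can be read from these values.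

One measured step links two of them directly: a number 9.7 percentage points higher from compound 2 to compound 3 (within the scatter). The next compound, compound 4 `O=C(NO)c1ccc(NCc2nc(-c3ccccc3)nn2-c2ccccc2)cc1`, arises from compound 3 by a single change: hydrogen in place of fluoro on an aromatic carbon. Going by the values given here, the only measured step that bears on this change is the one from compound 2 to compound 3, where exchanging one halogen-bearing ring for another moved the number by less than the scatter. Compound 1 also carries a plain phenyl in place of the halogen-bearing ring, though it differs from compound 4 elsewhere too, and its value sits close to that of compound 3.

Removing the single fluorine is therefore expected to leave the inhibition essentially unchanged, with a step of a number 5.9 percentage points lower from compound 3 to compound 4 (within the scatter) that stays within the scatter. For compound 4 the estimate is 65%, expected to fall between 50% and 78%.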

Compound 4, a percentage reported as inhibition, at one concentration (the size of the read-out at that concentration, not a potency): 72.6%
Beside the measured number, compound 4's estimate is 7.6 percentage points below it; measured number inside the range.
By their numbers in this assay, from the lowest: compounds 2, 1, 3 and 4 (each within the scatter of the next, the first and the last beyond it).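

In this assay, the fluoro group on the aromatic carbon para to a large group can give way to hydrogen with no change beyond the scatter (a number 1.7 percentage points higher from compound 3 to compound 4 (within the scatter)), so at this concentration the plain phenyl serves as well as the 4-fluorophenyl. Set against the other two compounds that differ from compound 4 in one place, hydrogen in place of chloro gives the only one of these new steps that clears the scatter, and only modestly (a number 11.4 percentage points higher from compound 2 to compound 4 (beyond the scatter)), while hydrogen in place of methoxy stays within it (a number 9.2 percentage points higher from compound 1 to compound 4 (within the scatter)), so among these compounds, neither the fluoro nor the methoxy group shows a measurable gain over hydrogen, and the chloro group sits on the losing side of a small step. No measurement here explains these small differences or says what lies behind them.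

Still open, from the compounds shown here alone, is whether a quite different group on the same carbon, such as an amine or a carboxylic acid, would shift the number by more than the scatter. Each value also comes from a single concentration and is not a potency, so compound 3 and compound 4 could still differ at other concentrations.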